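Swapping Naphthalene for Methoxyphenyl: an Expected Loss

This account rests on a few compounds, and the source may have more. Where it says the series, first, only, none or still open, it means among the compounds named here.

Compound 1, `CC(C)N(Cc1cccc(OCCCCCC(=O)O)c1)C(=O)c1ccc(-c2cccc3ccccc23)cc1`: in an ADME assay on BJ cells (Homo sapiens) for cytotoxicity, read by CellTiter-Glo and resazurin assay, with a stated time of 72 h (a lower number here means that less compound is needed, a higher number that more compound is needed for the effect), compound 1 gives < 1.3 nM, which is a limit of the assay rather than a number.
Compound 2, `CC(=O)Nc1cccc(-c2ccc(C(=O)N(Cc3cccc(OCCCCCC(=O)O)c3)C(C)C)cc2)c1`: in this assay compound 2 gives > 26000 nM, also a limit.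
Compound 3, `CC(C)N(Cc1cccc(OCCCCCC(=O)O)c1)C(=O)c1ccc(-c2cccc(OCc3ccccc3)c2)cc1`: in this assay compound 3 gives > 26000 nM, again a limit.

Compound 1 therefore stands at the low end of what this assay can report; its value is only a limit (the limit of < 1.3 nM in this assay, at which 1 of the 3 values shown sits), and the two other values shown are limits as well (the limit of > 26000 nM in this assay, at which 2 of the 3 values shown sit). Compound 4, `COc1cccc(-c2ccc(C(=O)N(Cc3cccc(OCCCCCC(=O)O)c3)C(C)C)cc2)c1`, differs from compound 1 in one place: 3-methoxyphenyl in place of naphthalen-1-yl on an aromatic carbon.

The measured step that bears on this change is an at least 20000-fold higher number from compound 1 to compound 2 (4.30 log units; beyond the scatter), in which a single substituted phenyl ring, 3-acetamidophenyl, took the place of the naphthalen-1-yl group, just as 3-methoxyphenyl does here. The further step that the two limits leave unreadable from compound 2 to compound 3 cannot be sized, but both compound 2 and compound 3 sit at the upper limit. A large upward step in this assay is therefore expected from compound 1 to compound 4, of about an at least 15000-fold higher number from compound 1 to compound 4 (4.18 log units; beyond the scatter). Compound 4 is estimated to give 20000 nM, with a likely range from 1500 nM to 60000 nM, and may well come out as a limit only.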

Compound 4, half-maximal effective concentration: > 20900 nM
Compound 4 was reported as a limit (the forecaster's own chance of this, stated with the estimate: 60%); at least 1.0-fold (0.01 log units) between middle value and limit.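

Replacing naphthalen-1-yl with 3-methoxyphenyl gives an at least 16000-fold higher number from compound 1 to compound 4 (4.20 log units; beyond the scatter) in this assay, so a second substituted phenyl ring at this position, para to a large group, ends far from compound 1. The large rise therefore does not depend on the acetamido group of compound 2: among the four compounds, only compound 1, with its two-ring naphthalen-1-yl group, sits at the low end, while compound 2, compound 3 and compound 4 all sit at upper limits. The steps among these last three cannot be read, and the value of compound 4 is itself a limit: the limit of > 20900 nM in this assay, at which 1 of the 4 values shown sits.

From the compounds shown here alone, it remains open whether a plain phenyl ring without a substituent would behave like compound 4 or like compound 1. A naphthalen-2-yl group would show whether the second ring alone is enough, or whether its point of attachment also matters.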